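Swapping the aryl ether substituent in a pyrazole amide series

The compounds below may be only part of what the source reports. "The series", "measured", "known", "first", "only" and "open" are said of these compounds alone.

Of the compounds shown here, three have been measured in a functional assay on MIA PaCa-2 cells (Homo sapiens) for antiproliferative activity, read by MTT assay, with a stated time of 72 h; a higher number here means that more compound is needed for the effect, a lower number that less compound is needed. Compound 1 `Cc1nn(Cc2cccc(C(=O)NC(C)C)c2)c(C)c1NC(=O)c1ccc(COc2ccccc2)cc1` gives 8900 nM, compound 2 `Cc1nn(Cc2cccc(C(=O)Nc3ccccc3)c2)c(C)c1NC(=O)c1ccc(COc2ccccc2)cc1` gives 6400 nM, and compound 3 `CNC(=O)c1cccc(Cn2nc(C)c(NC(=O)c3ccc(COc4cccc(C)c4)cc3)c2C)c1` gives 6200 nM. For the measured compounds named here, compound 3 holds the lowest of the three numbers, but every gap among them lies within the scatter; the one single-point step, a 1.4-fold lower number from compound 1 to compound 2 (0.14 log units; within the scatter), also stays within it. Compound 4 `CNC(=O)c1cccc(Cn2nc(C)c(NC(=O)c3ccc(COc4ccccc4Cl)cc3)c2C)c1` differs from compound 3 by 2-chlorophenyl in place of 3-methylphenyl on an oxygen on a saturated carbon. Going by the values given here, no measured step touches that part of the molecule, so nothing here points to a change beyond the scatter, and the step from compound 3 to compound 4 is expected to be no change at the digits printed from compound 3 to compound 4 (within the scatter). Compound 4 is therefore estimated at 6200 nM in this assay, within a range of 2500 nM to 15000 nM.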

Compound 4, half-maximal effective concentration: 6300 nM
Beside the measured number, compound 4's estimate is 1.0-fold (0.01 log units) below it; the range from low to high includes it.
By their numbers in this assay, from the lowest: compounds 3, 4, 2 and 1 (each within the scatter of the next).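

For the compounds shown here, this is the only measured step at this position: 2-chlorophenyl in place of 3-methylphenyl on the oxygen gives a 1.0-fold higher number from compound 3 to compound 4 (0.01 log units; within the scatter) in this assay. At this place, then, a ring carrying chlorine and a ring carrying methyl cannot be told apart in this assay. Nothing in the data shown speaks to the reason for this.

Still open, from the compounds shown here alone, is whether a ring bearing a carboxylic acid or an amine would move the number beyond the scatter. A single step also cannot say whether this swap would behave alike with the amide groups of compound 1 and compound 2.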